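Series notes: epoxide in place of isobutyl on the shared core

A few compounds are considered here, and "the series" means these few. Any claim that something is new, unique, unknown or untested is made for them only; others in the source may bear on it.

Measured compounds:
compound 1, `C#CCO/N=C1/C[C@@H](c2ccc(OC)cc2)Oc2cc(OC)c(CC=C(C)C)cc21`, gives 41%
compound 2, `COc1ccc([C@@H]2CC(=O)c3cc(CC=C(C)C)c(OC)cc3O2)cc1`, gives 58%
compound 3, `COc1cc2c(cc1CCC(C)C)C(=O)C[C@@H](c1ccc(O)cc1)O2`, gives 78%

All three were run in a functional assay on PC-3 cells (Homo sapiens) for inhibition, read by sulforhodamine B assay, with a stated time of 48 h, tested at 50 uM; on this read-out lower numbers stand for less inhibition of growth and higher numbers for more inhibition of growth at the one concentration tested. Compound 3 stands highest of the three numbers. Compound 2 sits lower, a gap beyond the scatter. Compound 1 sits furthest off, also beyond the scatter. No pair among these differs in one place, so no measured step guides the next change.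

Compound 4, `COc1cc2c(cc1CC1OC1(C)C)C(=O)C[C@@H](c1ccc(O)cc1)O2`, is compound 3 with 3,3-dimethyloxiran-2-yl in place of isobutyl on a saturated chain carbon bound to an aromatic carbon. The group that enters carries one hydrogen-bond acceptor and a three-membered ring where the isobutyl carried none. With nothing measured on such a change, the expected step of a number 8 percentage points lower from compound 3 to compound 4 (within the scatter) is small and downward, close to the scatter. Compound 4 is expected to give 70%, within 45% to 90%.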

Compound 4, percent growth inhibition at one concentration: 92%
Beside the measured number, compound 4's estimate is 22 percentage points below it; measured number outside the range, above it.
By their numbers in this assay, from the lowest: compound 1; then compound 2; then compound 3; then compound 4.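

In this assay, among these compounds, 3,3-dimethyloxiran-2-yl in place of isobutyl on a saturated chain carbon bound to an aromatic carbon gives a number 14 percentage points higher from compound 3 to compound 4 (beyond the scatter), the only single-place step. This place therefore accepts a three-membered ring carrying a hydrogen-bond acceptor, with the number rising rather than falling. No data at hand bear on what lies behind the rise.

Still open, as far as these compounds go, is whether the rise needs the intact three-membered ring. An open-chain diol or an amine in the same place would test this.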